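Allyl on the Ring Nitrogen: From One Core to Another

The compounds below may be only part of what the source reports. "The series", "measured", "known", "first", "only" and "open" are said of these compounds alone.

Compound 1 `c1ccc2c(c1)CCNC2c1ccc2ccccc2c1` and compound 2 `C=CCN1CCc2ccccc2C1c1ccc2ccccc2c1` share a core and differ only in that compound 2 carries an allyl group on the ring nitrogen (allyl in place of hydrogen on an amine nitrogen in a ring). In an assay on isolated protein for binding affinity to Sigma non-opioid intracellular receptor 1 (Rattus norvegicus) (on this read-out lower numbers stand for stronger inhibition and higher numbers for weaker inhibition), compound 1 gives 10000 nM, and compound 2 gives 11000 nM; the step of a 1.1-fold higher number from compound 1 to compound 2 (0.04 log units; within the scatter) is small and within the scatter.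

Compound 3 `CC(C)C1NCCc2ccsc21` is built on a different core; how the two cores differ is not broken down here. In this assay compound 3 gives 3800 nM, the lowest of the three numbers, beyond the scatter from both compound 1 and compound 2.

Compound 4 `C=CCN1CCc2ccsc2C1C(C)C` has not yet been measured. It differs from compound 3 by allyl in place of hydrogen on an amine nitrogen in a ring. This is the same kind of change as that from compound 1 to compound 2: the places are described as next to the ring atom that bears an isopropyl group in compound 3, and next to the ring atom that bears a large group in compound 1. Since the allyl group left the number almost unchanged in a 1.1-fold higher number from compound 1 to compound 2 (0.04 log units; within the scatter), the expectation for compound 4 is a step of about a 1.1-fold higher number from compound 3 to compound 4 (0.04 log units; within the scatter), essentially flat, resting on that single earlier step and on the value of compound 3 at 3800 nM. Compound 4 is therefore expected to give about 4200 nM, with a range from 1500 nM to 12000 nM.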

Compound 4, half-maximal inhibitory concentration: 5000 nM
For compound 4 the middle estimate is 1.2-fold (0.08 log units) below the measured one, within the range that was stated.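

In this assay, putting allyl in place of hydrogen on the ring nitrogen of compound 3 gives a 1.3-fold higher number from compound 3 to compound 4 (0.12 log units; within the scatter), so on this core too the change produces no step beyond the scatter. Set side by side, the two steps cannot be told apart, and in this small set the change carries from one core to the other without a detectable difference: the same change on two cores in this assay, a 1.1-fold higher number (0.04 log units; within the scatter) from compound 1 to compound 2 and a 1.3-fold higher number (0.12 log units; within the scatter) from compound 3 to compound 4, 1.2-fold (0.08 log units) apart, within the scatter of two such steps. This holds only for one group on two cores in one assay, and it does not show that allyl would be equally silent on any further core, that another group on the same nitrogen would behave alike, or why both steps are so small.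

The compounds shown leave open whether a propyl chain, a longer alkyl chain or a benzyl group on the ring nitrogen would also give a step within the scatter, or whether a chain ending in an amine or a carboxylic acid would give a larger one. They also leave open how the allyl step would read if a methyl or a cyclohexyl group took the place of the isopropyl group on the neighbouring ring atom of compound 4.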